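Replacing a cyclohexylethyl chain with a benzyl group

The source may hold more compounds than are shown below. What is called first, only, known or untested is meant among the compounds shown, and "the series" means these compounds.

The measured compounds:
- compound 1 `COc1cccc(Cc2cnc(CCc3ccc(-c4ccccc4C(=O)O)cc3)[nH]2)c1`: 4120 nM
- compound 2 `Cc1cccc(Cc2cnc(CCc3ccc(-c4ccccc4C(=O)O)cc3)[nH]2)c1`: 4310 nM
- compound 3 `O=C(O)c1ccccc1-c1ccc(CCc2ncc(CCC3CCCCC3)[nH]2)cc1`: 642 nM

All three share a core in which a biphenyl carboxylic acid is joined through a two-carbon chain to an imidazole, and they differ only in the group on the far side of that imidazole. In an in vitro functional assay on cells for agonist activity at Bombesin receptor subtype-3 (Homo sapiens), read by luminescence and calcium flux (on this read-out higher numbers stand for an effect only at larger amounts of compound and lower numbers for an effect already at smaller amounts), compound 1 gives 4120 nM and compound 2 gives 4310 nM; the step of a 1.0-fold higher number from compound 1 to compound 2 (0.02 log units; within the scatter) is within the scatter. Compound 3, with a cyclohexylmethyl group on a saturated chain carbon bound to an aromatic carbon, gives 642 nM, the lowest of the three numbers. The steps of a 6.4-fold lower number from compound 1 to compound 3 (0.81 log units; beyond the scatter) and a 6.7-fold lower number from compound 2 to compound 3 (0.83 log units; beyond the scatter) are both modest and beyond the scatter.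

Compound 4 `O=C(O)c1ccccc1-c1ccc(CCc2ncc(Cc3ccccc3)[nH]2)cc1` has not been measured. Its difference from compound 3 is phenyl in place of cyclohexylmethyl on a saturated chain carbon bound to an aromatic carbon. The two steps that bear on this change run in the opposite direction: swapping a substituted arylmethyl group for the cyclohexylethyl chain lowered the number in a 6.4-fold lower number from compound 1 to compound 3 (0.81 log units; beyond the scatter) and a 6.7-fold lower number from compound 2 to compound 3 (0.83 log units; beyond the scatter). Compound 4 carries a plain benzyl group, close to the arylmethyl groups of compound 1 and compound 2, so a step back toward their numbers is expected, though the missing ring substituent leaves its exact size open.

For compound 4 a value of 2500 nM is estimated, with a range from 800 nM to 8000 nM, corresponding to an expected step of a 3.9-fold higher number from compound 3 to compound 4 (0.59 log units; beyond the scatter).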

Compound 4, half-maximal effective concentration: 205 nM
For compound 4 the middle estimate is 12-fold (1.09 log units) above the measured one; measured number below the stated range.
By their numbers in this assay, from the lowest: compound 4; then compound 3; then compounds 1 and 2 (each within the scatter of the next).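

In this assay, the change from 2-cyclohexylethyl to benzyl gives a 3.1-fold lower number from compound 3 to compound 4 (0.50 log units; beyond the scatter), so an aromatic ring at this place does not by itself hold a compound at the higher numbers of compound 1 and compound 2. The large penalty instead goes with the substituent on that ring: hydrogen in place of methyl on an aromatic carbon gives a 21-fold lower number from compound 2 to compound 4 (1.32 log units; beyond the scatter), and removing the methoxy group from that ring gives a 20-fold lower number from compound 1 to compound 4 (1.30 log units; beyond the scatter), while the step between the two substituted compounds, a 1.0-fold higher number from compound 1 to compound 2 (0.02 log units; within the scatter), stays within the scatter. No measurement shown here explains why the unsubstituted benzyl group gives the lowest number of the four.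

Compound 3 and compound 4 differ in both ring type and chain length, and a 2-phenylethyl group at this place would help separate those two changes. On these data alone, it also remains open whether a substituent as small as fluorine on the benzyl ring would bring a step as large as those seen with methyl and methoxy, or whether the number would stay close to that of compound 4.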